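Fluorophenyl Amide in Place of a Heptyl Chain

A few compounds are considered here, and "the series" means these few. Any claim that something is new, unique, unknown or untested is made for them only; others in the source may bear on it.

Measured compounds and their values:
Compound 1, `CN1CCC(c2c[nH]c3cnc(NC(=O)c4ccc(F)cc4)cc23)CC1`: 53 nM
Compound 2, `CC(=O)Nc1cc2c(C3CCN(C)CC3)c[nH]c2cn1`: 39 nM
Compound 3, `CCCCCCCC(=O)Nc1ccc2[nH]cc(C3CCN(C)CC3)c2n1`: 110 nM

In an assay for binding affinity to 5-hydroxytryptamine receptor 1D (Homo sapiens), read by radioligand binding (on this read-out lower numbers stand for stronger inhibition and higher numbers for weaker inhibition), compound 3 gives the highest of the three numbers. Compound 1 stands nearest to it with a lower number, and compound 2 furthest with a still lower number; both gaps lie beyond the scatter. Compound 4, `CN1CCC(c2c[nH]c3ccc(NC(=O)c4cccc(F)c4)nc23)CC1`, has not been measured. It differs from compound 3 in one place: 3-fluorophenyl in place of heptyl on a carbonyl carbon.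

For the measured compounds named here, one measured step bears on this change. Between compound 1 and compound 2 an aryl group on the same carbonyl carbon was exchanged for a small alkyl group, and the result was a 1.4-fold lower number from compound 1 to compound 2 (0.13 log units; within the scatter). That step shows that an aryl and a short alkyl group on this carbonyl carbon gave numbers close to each other, while the longer heptyl chain of compound 3 gave the highest number of the set. On this basis the exchange in compound 4 is expected to move the number back toward the range of compound 1 and compound 2, that is, to a lower number.

The step expected from compound 3 to compound 4 is therefore a 2.2-fold lower number from compound 3 to compound 4 (0.34 log units; beyond the scatter). Compound 4 is estimated at 50 nM, with a range from 25 nM to 110 nM.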

Compound 4, inhibition constant: 690 nM
Compound 4: the middle estimate sits 14-fold (1.14 log units) below what was measured; the measured number lies above the stated range.
By their numbers in this assay, from the lowest: compounds 2 and 1 (each within the scatter of the next); then compound 3; then compound 4.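

In this assay, exchanging heptyl for 3-fluorophenyl on the carbonyl carbon gave a 6.3-fold higher number from compound 3 to compound 4 (0.80 log units; beyond the scatter) on the core shared by these two compounds, so here the aromatic ring is the less favourable of the two groups, although both carry the same count of heavy atoms and neither has a hydrogen-bond donor or acceptor. The earlier step, a 1.4-fold lower number from compound 1 to compound 2 (0.13 log units; within the scatter), belongs to a different core and involves 4-fluorophenyl and methyl, so the closeness of those two numbers does not carry over to the core of compound 3 and compound 4. Nothing shown here accounts for the rise in the number.

As far as these compounds go, whether the rise follows from the aromatic ring itself or from the fluorine on it stays open, and an unsubstituted phenyl or a 4-fluorophenyl on this carbonyl carbon would separate the two. From the compounds shown here alone, it is also open whether a methyl or a chain of intermediate length on the core of compound 3 would give a lower number than the heptyl chain does.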